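Ring substituent changes in an anilinoquinazoline antiproliferative series

The source may hold more compounds than are shown below. What is called first, only, known or untested is meant among the compounds shown, and "the series" means these compounds.

Measured compounds:
compound 1 `CCN(CC)CCCOc1cc2ncnc(Nc3ccc(C#N)cc3)c2cc1OC`, 59400 nM
compound 2 `COc1cc2c(Nc3ccc(C#N)cc3)ncnc2cc1OCCCN1CCCCC1`, 20700 nM
compound 3 `COc1cc2c(Nc3ccc(C#N)cc3)ncnc2cc1OCCCN1CCC(O)CC1`, 67900 nM

In a functional assay on HepG2 cells (Homo sapiens) for antiproliferative activity, read by MTT assay, with a stated time of 72 h (a lower number here means a stronger inhibitor, a higher number a weaker inhibitor), compound 3 gives 67900 nM, the highest of the three numbers. Within the data shown here, the step of a 1.1-fold higher number from compound 1 to compound 3 (0.06 log units; within the scatter) is within the scatter, so those two are not separable; only the step of a 3.3-fold higher number from compound 2 to compound 3 (0.52 log units; beyond the scatter) is beyond the scatter.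

Compound 4 `CCOC(=O)C1CCN(CCCOc2cc3ncnc(Nc4ccc(C#N)cc4)c3cc2OC)CC1` is not yet measured. The change from compound 3 is ethoxycarbonyl in place of hydroxy on a saturated ring carbon.

Among the measured compounds shown here, the only measured step at the same place is a 3.3-fold higher number from compound 2 to compound 3 (0.52 log units; beyond the scatter), where a hydroxy entered in place of hydrogen. For the measured compounds named here, no step here exchanges one substituent for another on that ring carbon, and no step brings in an ethoxycarbonyl, so the data give no direct template for this change. The other steps, a 2.9-fold lower number from compound 1 to compound 2 (0.46 log units; beyond the scatter) and a 1.1-fold higher number from compound 1 to compound 3 (0.06 log units; within the scatter), concern the amine itself rather than a substituent on it and bear only indirectly.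

Going by the values given here, with no guiding precedent, the expected step of a 1.5-fold lower number from compound 3 to compound 4 (0.18 log units; within the scatter) for compound 4 is taken as small and of uncertain direction, with a wide range. Compound 4 is estimated at 45000 nM, between 15000 nM and 130000 nM.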

Compound 4, half-maximal inhibitory concentration: 57700 nM
For compound 4 the middle estimate is 1.3-fold (0.11 log units) below the measured one; the range from low to high includes it.
By their numbers in this assay, from the lowest: compound 2; then compounds 4, 1 and 3 (each within the scatter of the next).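

In this assay the step of a 1.2-fold lower number from compound 3 to compound 4 (0.07 log units; within the scatter) lies within the scatter, so at this saturated ring carbon, three ring bonds from the ring nitrogen, ethoxycarbonyl and hydroxy cannot be separated, although ethoxycarbonyl brings 5 heavy atoms and 0 hydrogen-bond donors. Measured against the unsubstituted piperidin-1-yl of compound 2, the step of a 2.8-fold higher number from compound 2 to compound 4 (0.45 log units; beyond the scatter) is beyond the scatter and has the same direction as the step of a 3.3-fold higher number from compound 2 to compound 3 (0.52 log units; beyond the scatter) seen with hydroxy, so two different groups at this ring carbon now both give a higher number than hydrogen. The step of a 1.0-fold lower number from compound 1 to compound 4 (0.01 log units; within the scatter) leaves 4-(ethoxycarbonyl)piperidin-1-yl and diethylamino inseparable as well, and nothing at hand gives a reason for any of these steps.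

On these data alone, whether a carboxylic acid, a primary amide or an aminomethyl group on the same ring carbon would also stay with compounds 3 and 4 or come back towards compound 2 remains open. Also open, as far as these compounds go, is whether a longer chain between the aromatic oxygen and the ring nitrogen would change the step from hydrogen to ethoxycarbonyl.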